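Bromo substitution on the compound 1 scaffold

The source may hold more compounds than are shown below. What is called first, only, known or untested is meant among the compounds shown, and "the series" means these compounds.

Measured compounds:
compound 1 `O=C1NC[C@@H](c2c[nH]c3ccccc23)N[C@H]1c1c[nH]c2ccccc12` 9.64 ug/mL
compound 2 `O=C(C1=NC(c2c[nH]c3cc(Br)ccc23)CN1)c1c[nH]c2ccccc12` 3.71 ug/mL
compound 3 `O=C1NC[C@H](c2c[nH]c3cc(Br)ccc23)N=C1c1c[nH]c2cc(Br)ccc12` 2.61 ug/mL

In an ADME assay on SK-OV-3 cells (Homo sapiens) for cytotoxicity (on this read-out lower numbers stand for an effect already at smaller amounts and higher numbers for an effect only at larger amounts of compound), compound 1 gives 9.64 ug/mL, the highest of the three numbers. Compound 2 gives 3.71 ug/mL and compound 3 gives 2.61 ug/mL; both differences to compound 1 lie beyond the scatter. Compounds 2 and 3 each differ from compound 1 in more than one place, so nothing more than their values can be read from them.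

Compound 4 `O=C1NC[C@@H](c2c[nH]c3cc(Br)ccc23)N[C@H]1c1c[nH]c2ccccc12` is not yet measured in this assay. It differs from compound 1 by a single change: bromo in place of hydrogen on an aromatic carbon. Both measured compounds carrying a bromo substituent show lower numbers than compound 1, which gives some reason to expect a move in the same direction, though neither of them is a one-step comparison with compound 1.

For compound 4 the expected step in this assay is a 1.8-fold lower number from compound 1 to compound 4 (0.24 log units; within the scatter), a modest move towards lower numbers, possibly beyond the scatter. The estimate for compound 4 is therefore 5.5 ug/mL, within a range of 2.5 ug/mL to 11 ug/mL.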

Compound 4, concentration for half-maximal effect: 6 ug/mL
Compound 4: middle estimate off by 1.1-fold (0.04 log units), on the low side; low and high end bracket the measured number.
By their numbers in this assay, from the lowest: compounds 3, 2, 4 and 1 (each within the scatter of the next, the first and the last beyond it).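

In this assay, among these compounds, bromo in place of hydrogen on an aromatic carbon, meta to a fused ring and para to a fused ring, gives a 1.6-fold lower number from compound 1 to compound 4 (0.21 log units; within the scatter) and provides the first one-place comparison. Among the compounds shown here, at this position on the core of compound 1, bromo therefore produces no step that can be read beyond the scatter, so this single change gives no clear shift on this read-out. No measurement on hand offers an explanation for this result.

Compounds 2 and 3 still differ from compound 1 in more than one place, so the single-bromo result does not settle how their values should be read. Open questions are whether fluoro, chloro, methoxy, an amine or a carboxylic acid on the same aromatic carbon would give a step beyond the scatter, and whether bromo on a different aromatic carbon of the core would do so.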